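From methylsulfanyl to tert-butyl on the shared core

The source may hold more compounds than are shown below. What is called first, only, known or untested is meant among the compounds shown, and "the series" means these compounds.

In a functional assay on SK-MEL-5 cells (Homo sapiens) for cytotoxicity (on this read-out higher numbers stand for an effect only at larger amounts of compound and lower numbers for an effect already at smaller amounts), compound 3 (`COc1cc(/C=C/c2ccc(SC)cc2)cc(OC)c1OC`) gives 2.8 uM as its measured value. That sits within the usual scatter of compound 2 (`COc1cc(/C=C\c2ccc(C(C)(C)C)cc2)cc(OC)c1OC`), which reads 2.1 uM here, and clearly under compound 1 (`COc1cc(/C=C/c2ccc(C(C)C)cc2)cc(OC)c1OC`), which reads 11.1 uM on the same scale.

The next structure, compound 4 (`COc1cc(/C=C/c2ccc(C(C)(C)C)cc2)cc(OC)c1OC`), has tert-butyl in place of methylsulfanyl on an aromatic carbon. Going by the values given here, only one measured step touches this position with a single change. It is a 4.0-fold lower number from compound 1 to compound 3 (0.60 log units; beyond the scatter) when methylsulfanyl takes the place of isopropyl, a modest step but one beyond the scatter. Compound 4 shares the geometry of its double bond with compound 1, and it carries tert-butyl where compound 1 carries isopropyl. Compound 2 also has tert-butyl, but its double bond has the opposite geometry, which makes it a less direct guide. Leaving methylsulfanyl may therefore largely undo the measured step, so a move towards higher numbers is expected. The expected change in this assay is a 2.9-fold higher number from compound 3 to compound 4 (0.46 log units; beyond the scatter) as a rough estimate. Compound 4 is estimated at 8 uM with an expected range from 3 uM to 20 uM in this read-out.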

Compound 4, concentration for half-maximal effect: > 25 uM
Compound 4: only a limit was reported (the forecaster's own chance of this, stated with the estimate: 3%); at least 3.1-fold (0.49 log units) between middle value and limit.
By their numbers in this assay, from the lowest: compounds 2 and 3 (each within the scatter of the next); then compound 1. At a limit, above all of these: compound 4.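

In this assay compound 4 gives > 25 uM, which is a limit and not a number: the limit of > 25 uM in this assay, at which 1 of the 4 values shown sits. Going by these compounds alone, the earlier compounds offered only one single-change step at this position, and the new steps show that the group placed here can move the read-out further, with an at least 8.9-fold higher number from compound 3 to compound 4 (0.95 log units; beyond the scatter) when tert-butyl replaces methylsulfanyl and an at least 2.2-fold higher number from compound 1 to compound 4 (0.35 log units; beyond the scatter) when one added methyl turns isopropyl into tert-butyl. Tert-butyl alone does not settle the outcome, since the step with no change of group at all, a double bond drawn Z in one compound and E in the other, is an at least 11-fold higher number from compound 2 to compound 4 (1.07 log units; beyond the scatter), and the comparison is a clean one: the fact that compounds 2 and 4 differ only in the configuration as drawn.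

Going by these compounds, how far past its limit compound 4 really lies stays open, and so does whether the double-bond geometry would matter as much with methylsulfanyl or isopropyl in this place. Also open, on these data alone, is how an amine or a carboxylic acid at this position on the shared core would read on this scale.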